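The source may report more compounds than this note shows. Statements on the series, on what has been measured and on what is new or still open speak of the compounds shown alone.

Measured in a functional assay on ECa-109 cells (Homo sapiens) for cytotoxicity, read by MTT assay, with a stated time of 72 h; a higher number here means a weaker inhibitor, a lower number a stronger inhibitor:
- compound 1 `O=C1C(=Cc2ccc(O)cc2)C(=O)N(c2ccc(Cl)cc2)N1c1ccc(Cl)cc1`: 34200 nM
- compound 2 `O=C1C(=Cc2ccc(Cl)cc2)C(=O)N(c2ccc(Cl)cc2)N1c1ccc(Cl)cc1`: 17300 nM
- compound 3 `O=C1C(=Cc2cccc(Cl)c2)C(=O)N(c2ccc(Cl)cc2)N1c1ccc(Cl)cc1`: 22600 nM

Compound 3, at 22600 nM, sits within the scatter of both other compounds, so the three values cannot be ranked with any confidence.

The next compound is compound 4 `COc1ccccc1C=C1C(=O)N(c2ccc(Cl)cc2)N(c2ccc(Cl)cc2)C1=O`. Its change from compound 3 is 2-methoxyphenyl in place of 3-chlorophenyl on a double-bonded chain carbon bound to a double-bonded ring carbon. The core and both 4-chlorophenyl-bearing ring positions stay as they are, and only the aromatic group on the double-bonded chain carbon is exchanged.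

Within the data shown here, three measured steps bear on this place, and all of them alter that same aromatic group: a 2.0-fold lower number from compound 1 to compound 2 (0.30 log units; within the scatter), a 1.5-fold lower number from compound 1 to compound 3 (0.18 log units; within the scatter) and a 1.3-fold higher number from compound 2 to compound 3 (0.12 log units; within the scatter). None of them leaves the scatter, so the series has so far shown little response in this assay to changes at this place. That evidence is thin. Among the measured compounds shown here, no measured compound carries 2-methoxyphenyl, and none shows what a methoxy group does here.

No step beyond the scatter is therefore expected, in either direction. The expected step is a 1.1-fold higher number from compound 3 to compound 4 (0.03 log units; within the scatter). For compound 4 the estimated value is 24000 nM, with an expected range of 11000 nM to 52000 nM.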

Compound 4, half-maximal inhibitory concentration: 30400 nM
Estimate against measurement, compound 4: 1.3-fold (0.10 log units) below; low and high end bracket the measured number.
By their numbers in this assay, from the lowest: compounds 2, 3, 4 and 1 (each within the scatter of the next).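

In this assay, among these compounds, 2-methoxyphenyl is the first group at this place to carry a methoxy group, and the values stay close together: a 1.3-fold higher number from compound 3 to compound 4 (0.13 log units; within the scatter) and a 1.8-fold higher number from compound 2 to compound 4 (0.24 log units; within the scatter) and a 1.1-fold lower number from compound 1 to compound 4 (0.05 log units; within the scatter) all lie within the scatter. The weak response seen among 4-hydroxyphenyl, 4-chlorophenyl and 3-chlorophenyl therefore extends to a fourth aromatic group, one with neither chlorine nor a hydroxy group, and none of the four compounds can be ranked against the others on these numbers. No measured evidence is available to explain this weak response.

From the compounds shown here alone, it remains open whether any group on the double-bonded chain carbon can move the number beyond the scatter, as all four compounds carry a phenyl ring with a single substituent there, and a dimethylamino group, a carboxylic acid or a longer alkoxy chain on that ring would extend the comparison. The two 4-chlorophenyl groups are the same in all four compounds, so the response to replacing either one, for example with an unsubstituted phenyl or a methyl group, is also unknown.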